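Replacing the 2-hydroxyphenyl group: clearance outlook for compound 3

This account rests on a few compounds, and the source may have more. Where it says the series, first, only, none or still open, it means among the compounds named here.

Among the measured compounds shown here, compound 2 `Nc1ccc(S(=O)(=O)N2CCN(c3ncc(C(O)(C(F)(F)F)C(F)(F)F)cc3-c3ccccc3O)CC2)cn1` stands highest of the two numbers so far in an ADME assay (liver) for metabolic stability, with Liver microsome (Rattus norvegicus) as the target, using microsomes and NADPH, with a stated time of 30 min, tested at 1 uM (on this read-out lower numbers stand for slow clearance and higher numbers for fast clearance), where compound 2 gives 125 mL.min-1.g-1. Compound 1 `Nc1ccc(S(=O)(=O)N2CCN(c3ncc(C(O)(C(F)(F)F)C(F)(F)F)cc3Br)CC2)cn1` gives 32 mL.min-1.g-1 in this assay, and the step of a 3.9-fold higher number from compound 1 to compound 2 (0.59 log units; beyond the scatter) came with 2-hydroxyphenyl in place of bromo on an aromatic carbon. Compound 3 `Nc1ccc(S(=O)(=O)N2CCN(c3ncc(C(O)(C(F)(F)F)C(F)(F)F)cc3-c3ccc4c(c3)CC(=O)N4)CC2)cn1` carries a group of 10 heavy atoms (8 carbon, 1 nitrogen, 1 oxygen; one five-membered non-aromatic ring with 1 hetero atom, one six-membered aromatic ring of carbon only) in place of a group of 7 heavy atoms (6 carbon, 1 oxygen; one six-membered aromatic ring of carbon only), on an aromatic carbon. For the measured compounds named here, only that one step is on hand, and it exchanges a different pair of groups, so it bears on the present change only loosely; no measured step replaces one aryl group by another. The expected step of a 1.0-fold lower number from compound 2 to compound 3 (0.02 log units; within the scatter) is therefore none beyond the scatter. Compound 3 is estimated at 120 mL.min-1.g-1, within 55 mL.min-1.g-1 to 260 mL.min-1.g-1.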

Compound 3, intrinsic clearance in microsomes: 119 mL.min-1.g-1
The estimate for compound 3 lay 1.0-fold (0.00 log units) above the measured number; low and high end bracket the measured number.
By their numbers in this assay, from the lowest: compound 1; then compounds 3 and 2 (each within the scatter of the next).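

In this assay, the group of 10 heavy atoms in place of 2-hydroxyphenyl leaves the number unmoved, with a 1.1-fold lower number from compound 2 to compound 3 (0.02 log units; within the scatter) as the step. In place of bromo the same group gives a 3.7-fold higher number from compound 1 to compound 3 (0.57 log units; beyond the scatter), so the higher number is not tied to 2-hydroxyphenyl alone and appears with both ring-bearing groups at this aromatic carbon. No measured evidence bears on the reason for this.

Going by these compounds, whether an amine or a carboxylic acid on this aromatic carbon would give a number nearer that of compound 1 stays open.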